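Furan-fused ester amides: swapping the sulfanyl aryl group

This account rests on a few compounds, and the source may have more. Where it says the series, first, only, none or still open, it means among the compounds named here.

Measured so far:
compound 1, `COC(=O)c1oc2ccccc2c1NC(=O)COc1ccc(Br)cc1`: 1050 nM
compound 2, `COC(=O)c1oc2cccc(Cl)c2c1NC(=O)CSc1ccccn1`: 646 nM

Among the compounds with values here, in an assay on H9c2 cells for inhibition of tumor necrosis factor receptor superfamily member 6 (Rattus norvegicus), with stated times of 30 min and 6 h (a lower number here means that less compound is needed, a higher number that more compound is needed for the effect), compound 2 gives 646 nM, the lowest of the two numbers so far; the nearest is compound 1, whose 1050 nM lies within the scatter, so the two cannot be ordered. Within the data shown here, no pair differing in a single place has been measured, so no step size is on record for this series.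

Compound 3, `COC(=O)c1oc2cccc(Cl)c2c1NC(=O)CSc1ccc(Br)cc1`, is not yet measured. It differs from compound 2 by 4-bromophenyl in place of pyridin-2-yl on a sulfur. The shared core of compound 2 and the carbonyl-bearing chain stay as they are. Among the measured compounds shown here, with no measured step to lean on, the expectation in this assay is a change of no more than the scatter, possibly a modest rise, given that compound 1, which also carries 4-bromophenyl on a chain, gives 1050 nM. The expected shift from compound 2 to compound 3 is a 1.4-fold higher number from compound 2 to compound 3 (0.14 log units; within the scatter). For compound 3 the estimate is 900 nM, with a range from 350 nM to 2500 nM.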

Compound 3, half-maximal effective concentration: 1150 nM
Beside the measured number, compound 3's estimate is 1.3-fold (0.11 log units) below it; low and high end bracket the measured number.
By their numbers in this assay, from the lowest: compounds 2, 1 and 3 (each within the scatter of the next).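

In this assay, within the data shown here, a 1.8-fold higher number from compound 2 to compound 3 (0.25 log units; within the scatter) is the first single-place step on record for this series, and it lies within the scatter. On this sulfur, 4-bromophenyl and pyridin-2-yl therefore cannot be ordered, even though the swap exchanges a ring with one hetero atom and one hydrogen-bond acceptor for an all-carbon ring carrying bromine. No measurement beyond these numbers bears on this result.

As far as these compounds go, both groups are six-membered aromatic rings, so it remains open whether a group of another kind on this sulfur, such as cyclohexyl, a longer alkyl chain or a chain ending in an amine or a carboxylic acid, would give a step beyond the scatter. The compounds shown also leave open whether the number responds to any other place on the shared core.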